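Swapping One Five-Membered Ring in Compound 1

This account rests on a few compounds, and the source may have more. Where it says the series, first, only, none or still open, it means among the compounds named here.

Of the compounds shown here, two have been measured in an assay on HEK293 cells for agonist activity at transient receptor potential cation channel subfamily M member 8 (Homo sapiens), read by fluorescence and calcium flux, with a stated time of 15 min; a higher number here means that more compound is needed for the effect, a lower number that less compound is needed. Compound 1 `CCN(Cc1ccoc1)C(=O)COc1ccc(C)cc1` gives 136 nM in this assay, the highest of the two numbers. Compound 2 `Cc1ccc(OCC(=O)N(Cc2cccs2)c2ccon2)cc1` gives 2 nM in this assay, a lower number than compound 1 by a gap that lies well beyond the usual scatter; since compound 2 differs from compound 1 in more than one place, nothing can be said about which part of the structure carries that gap.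

Compound 3 `CCN(Cc1cncs1)C(=O)COc1ccc(C)cc1` is not yet measured. It differs from compound 1 in a single place, (1,3-thiazol-5-yl in place of furan-3-yl on a saturated chain carbon bound to an amide-type nitrogen). Going by the values given here, the one ring that leaves and the one that enters are each five-membered aromatic rings of the same heavy-atom count, and no measured pair shows what this particular exchange does. The step from compound 1 to compound 3 is therefore expected to be small, most likely none beyond the scatter in either direction, as the estimate a 1.1-fold lower number from compound 1 to compound 3 (0.05 log units; within the scatter) conveys. Compound 3 is expected to give about 120 nM in this assay, within a range from 40 nM to 400 nM.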

Compound 3, half-maximal effective concentration: 1100 nM
Compound 3: middle estimate off by 9.2-fold (0.96 log units), on the low side; the whole stated range lies below it.
By their numbers in this assay, from the lowest: compound 2; then compound 1; then compound 3.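

In this assay, putting 1,3-thiazol-5-yl in place of furan-3-yl on a saturated chain carbon bound to an amide-type nitrogen gives an 8.1-fold higher number from compound 1 to compound 3 (0.91 log units; beyond the scatter), so this position is not indifferent to which five-membered aromatic ring it carries, even when the heavy-atom count stays the same. Since a higher number means that more compound is needed for the effect, the furan-3-yl of the core of compound 1 is the better of the two rings tried here, while the exchange takes the ring from 1 hetero atom to 2 and from 1 hydrogen-bond acceptor to 2. No measurement at hand explains the size or the direction of this step.

As far as these compounds go, with a single exchange in view at this position, it stays open whether a phenyl ring or a pyridin-3-yl in the same place would give a lower or a higher number than the furan-3-yl of compound 1. From the compounds shown here alone, it is also open whether the step goes with the sulfur or with the ring nitrogen of the 1,3-thiazol-5-yl, a question that a 1,3-oxazol-5-yl, with oxygen and nitrogen in its ring, could help to separate.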